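The source may hold more compounds than are shown below. What is called first, only, known or untested is meant among the compounds shown, and "the series" means these compounds.

Three compounds sharing one core, and differing only in the group on an aromatic carbon of a five-membered aromatic ring with 3 nitrogen, have been measured in a functional assay on A549 cells (Homo sapiens) for antiproliferative activity, read by MTT assay, with a stated time of 72 h; a higher number here means a weaker inhibitor, a lower number a stronger inhibitor. There compound 1 `CC(C)(C)c1cn(C[C@H](O)[C@H]2OC(=O)C(OCc3ccccc3)=C2OCc2ccccc2)nn1`, which carries tert-butyl, gives 34000 nM, compound 2 `O=C1O[C@H]([C@@H](O)Cn2cc(C3CC3)nn2)C(OCc2ccccc2)=C1OCc1ccccc1`, with cyclopropyl, gives 43900 nM, and compound 3 `COc1ccc(-c2cn(C[C@H](O)[C@H]3OC(=O)C(OCc4ccccc4)=C3OCc3ccccc3)nn2)cc1`, with 4-methoxyphenyl, gives 28300 nM. Compound 3 therefore stands level with the other two, within the scatter of both. The unmeasured compound 4 `O=C1O[C@H]([C@@H](O)Cn2cc(CCO)nn2)C(OCc2ccccc2)=C1OCc1ccccc1` has 2-hydroxyethyl in place of 4-methoxyphenyl on an aromatic carbon. Three measured steps at this same place bear on the change: a 1.3-fold higher number from compound 1 to compound 2 (0.11 log units; within the scatter), a 1.2-fold lower number from compound 1 to compound 3 (0.08 log units; within the scatter) and a 1.6-fold lower number from compound 2 to compound 3 (0.19 log units; within the scatter). Each lies within the scatter, so exchanging these three groups has not moved the number measurably in this assay. Within the data shown here, none of the measured compounds carries 2-hydroxyethyl, however, which limits how far these steps can guide the expectation. No step beyond the scatter is expected, and the estimated change is a 1.4-fold higher number from compound 3 to compound 4 (0.15 log units; within the scatter). For compound 4 the expected value is 40000 nM, with an estimated range from 18000 nM to 90000 nM.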

Compound 4, half-maximal inhibitory concentration: > 100000 nM
Compound 4 was reported as a limit; the forecaster's own chance of this, stated with the estimate: 20%; at least 2.5-fold (0.39 log units) between middle value and limit.
By their numbers in this assay, from the lowest: compounds 3, 1 and 2 (each within the scatter of the next). At a limit, above all of these: compound 4.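

In this assay compound 4 is reported as a limit, not as a number: the limit of > 100000 nM in this assay, at which 1 of the 4 values shown sits. This shows that the group on the aromatic carbon of the five-membered ring can matter: tert-butyl, cyclopropyl and 4-methoxyphenyl could be exchanged without a measurable difference, but 2-hydroxyethyl gives an at least 3.5-fold higher number from compound 3 to compound 4 (0.54 log units; beyond the scatter), an at least 2.2-fold higher number from compound 2 to compound 4 (0.35 log units; beyond the scatter) and an at least 2.9-fold higher number from compound 1 to compound 4 (0.46 log units; beyond the scatter). Loss of the six-membered aromatic ring of 4-methoxyphenyl does not by itself mark the change, since compound 1 and compound 2, with tert-butyl and cyclopropyl, stand within the scatter of compound 3, which leaves the hydrogen-bond donor that enters with 2-hydroxyethyl as the clearest remaining difference in the counted features, though only as an association.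

As far as these compounds go, how far the three steps extend past their stated minimum stays open. The compounds shown also leave open whether the hydroxyl itself separates 2-hydroxyethyl from the other groups, a question on which a plain ethyl group, a 2-methoxyethyl group or a 2-aminoethyl group at this place would bear.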